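The compounds below may be only part of what the source reports. "The series", "measured", "known", "first", "only" and "open" are said of these compounds alone.

Measured in a functional assay on the whole organism with Canis familiaris (Canis lupus familiaris) as the target; on this read-out higher numbers stand for an effect only at larger amounts of compound and lower numbers for an effect already at smaller amounts:
compound 1 `C/C=C\C=C\[C@](C)(O)C/C=C/[C@H]1[C@H](O)CC(=O)[C@@H]1CC/C=C\CCC(=O)OC` gives 0.0000099 mg/kg
compound 2 `COC(=O)CC/C=C\CC[C@H]1C(=O)C[C@@H](O)[C@@H]1/C=C/C[C@@](C)(O)/C=C/C(C)=C(C)C` gives 0.00006 mg/kg
compound 3 `COC(=O)CC/C=C\CC[C@H]1C(=O)C[C@@H](O)[C@@H]1/C=C/C[C@@](C)(O)/C=C/C1=CCCC1` gives 0.00002 mg/kg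

Compound 3 holds the second highest of the three numbers; nearest to it: a 2.0-fold higher number from compound 1 to compound 3 (0.31 log units; beyond the scatter); furthest from it: a 3.0-fold lower number from compound 2 to compound 3 (0.48 log units; beyond the scatter). Compound 4 `C=C/C=C/[C@](C)(O)C/C=C/[C@H]1[C@H](O)CC(=O)[C@@H]1CC/C=C\CCC(=O)OC` differs from compound 3 at one place: vinyl in place of cyclopent-1-en-1-yl on a double-bonded chain carbon bound to a double-bonded chain carbon. Within the data shown here, the steps that bear on this change are a 2.0-fold higher number from compound 1 to compound 3 (0.31 log units; beyond the scatter) and a 6.1-fold higher number from compound 1 to compound 2 (0.78 log units; beyond the scatter), both modest and both towards higher numbers in the order prop-1-en-1-yl, cyclopent-1-en-1-yl, 1,2-dimethylprop-1-en-1-yl; a 3.0-fold lower number from compound 2 to compound 3 (0.48 log units; beyond the scatter) runs back the other way. Among the measured compounds shown here, no measured compound carries vinyl, so the anchor is loose. Going from cyclopent-1-en-1-yl to vinyl, a modest step to a lower number is expected, a 2.0-fold lower number from compound 3 to compound 4 (0.30 log units; within the scatter). Compound 4 is estimated at 0.00001 mg/kg, in the range 0.000003 mg/kg to 0.00003 mg/kg.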

Compound 4, dose for half-maximal effect: 0.000007 mg/kg
The estimate for compound 4 lay 1.4-fold (0.15 log units) above the measured number, within the range that was stated.
By their numbers in this assay, from the lowest: compounds 4 and 1 (each within the scatter of the next); then compound 3; then compound 2.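

In this assay, vinyl at this place gives a 2.9-fold lower number from compound 3 to compound 4 (0.46 log units; beyond the scatter) and an 8.6-fold lower number from compound 2 to compound 4 (0.93 log units; beyond the scatter), while a 1.4-fold lower number from compound 1 to compound 4 (0.15 log units; within the scatter) leaves vinyl and prop-1-en-1-yl not told apart. The methyl end of prop-1-en-1-yl is therefore not required for the low numbers, and both cyclopent-1-en-1-yl and 1,2-dimethylprop-1-en-1-yl read higher than vinyl. No available evidence explains these steps. Still open, on these data alone, is how a phenyl ring, an amine or a carboxylic acid at this place would read in this assay.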